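A few compounds are considered here, and "the series" means these few. Any claim that something is new, unique, unknown or untested is made for them only; others in the source may bear on it.

Working notes on the series. Compound 1 `N#CC1=C(N)Oc2c(c3nc4ccccc4nc3c3ccccc23)C12C(=O)N(Cc1cnnn1-c1ccc([N+](=O)[O-])cc1)c1ccccc12` and compound 2 `Cc1ccc(-n2nncc2CN2C(=O)C3(C(C#N)=C(N)Oc4c3c3nc5ccccc5nc3c3ccccc43)c3ccccc32)cc1C` share one core; compound 3 `N#CC1=C(N)Oc2c(N)cc3nc4ccccc4nc3c2C12C(=O)N(Cc1cnnn1-c1ccc([N+](=O)[O-])cc1)c1ccccc12` and the unmeasured compound 4 `Cc1ccc(-n2nncc2CN2C(=O)C3(C(C#N)=C(N)Oc4c(N)cc5nc6ccccc6nc5c43)c3ccccc32)cc1C` share a second core. The difference between the two cores is not broken down here.

In a functional assay on HCT-116 cells (Homo sapiens) for antiproliferative activity, read by MTT assay, with a stated time of 48 h (a lower number here means a stronger inhibitor, a higher number a weaker inhibitor), compound 1 gives only a limit of the assay, > 50000 nM. In this assay compound 2 likewise gives only a limit, > 50000 nM. The change between them is 3,4-dimethylphenyl in place of 4-nitrophenyl on an aromatic nitrogen, and the resulting step is a step that the two limits leave unreadable from compound 1 to compound 2. In this assay compound 3 also gives only a limit, > 50000 nM. Going by the values given here, all values so far sit at the limit of > 50000 nM in this assay, at which 3 of the 3 values shown sit, so no readable step exists anywhere in the set.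

Compound 4 remains to be measured in this assay. Its change from compound 3 is 3,4-dimethylphenyl in place of 4-nitrophenyl on an aromatic nitrogen, the same change as from compound 1 to compound 2, at the same place. Among the compounds with values here, the step that the limit leaves unreadable from compound 3 to compound 4 is expected to stay unreadable, because the limit of > 50000 nM in this assay, at which 3 of the 3 values shown sit, holds for every compound measured so far, including the pair carrying this exact change. For compound 4 the expected value in this assay is 80000 nM, with an expected range from 30000 nM to 300000 nM, most likely reported again only as a limit.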

Compound 4, half-maximal inhibitory concentration: > 50000 nM
Compound 4 gave a limit, no number; the forecaster's own chance of this, stated with the estimate: 88%; the middle value is on the limit's open side.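

In this assay, going by these compounds alone, compound 4 gives only a limit of the assay (> 50000 nM), so no step from compound 3 to compound 4 can be read, and none can be read anywhere in the set: the limit of > 50000 nM in this assay, at which 4 of the 4 values shown sit. The compounds shown leave open whether 3,4-dimethylphenyl in place of 4-nitrophenyl makes any difference to antiproliferative activity on either core.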